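A Chloro Substituent and Paw Edema Inhibition

The source may report more compounds than this note shows. Statements on the series, on what has been measured and on what is new or still open speak of the compounds shown alone.

compound 1, `O=C(N/N=C/c1ccccc1)c1cccnc1Nc1cccc(C(F)(F)F)c1`: 21.2%
compound 2, `O=C(N/N=C/c1ccc(Cl)cc1)c1cccnc1Nc1cccc(C(F)(F)F)c1`: 48.5%
compound 3, `CNc1ncccc1C(=O)N/N=C/c1ccccc1`: 22.7%

In a functional assay on the whole organism (strain Wistar) for inhibition, with Rattus norvegicus as the target, read by paw edema, with a stated time of 3 h, at a dose of 10 mg/kg by the intraperitoneal route (on this read-out higher numbers stand for more inhibition at the one dose given (going by the name of the read-out) and lower numbers for less inhibition), compound 1 gives 21.2% and compound 2 gives 48.5%. The change between them, (chloro in place of hydrogen on an aromatic carbon), gave a step of a number 27.3 percentage points higher from compound 1 to compound 2 (beyond the scatter). Compound 3 has a different core; the difference between the two cores is not broken down here. Compound 4, `CNc1ncccc1C(=O)N/N=C/c1cccc(Cl)c1`, is not yet measured. The change from compound 3 to compound 4 is chloro in place of hydrogen on an aromatic carbon. For the measured compounds named here, it is the same kind of change as the one from compound 1 to compound 2, but not the same: there the chloro sits para to a large group, here meta to a large group. A smaller gain is therefore expected, an estimated step of a number 15.3 percentage points higher from compound 3 to compound 4 (beyond the scatter), because compound 3 starts from 22.7% and the earlier step was a number 27.3 percentage points higher from compound 1 to compound 2 (beyond the scatter). Compound 4 is expected to give about 38%, likely between 24% and 55%.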

Compound 4, a percentage reported as inhibition, in the whole organism at one dose (the size of the read-out at that dose, not a potency): 39.6%
For compound 4 the middle estimate is 1.6 percentage points below the measured one; the range from low to high includes it.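

In this assay chloro in place of hydrogen on an aromatic carbon again raises the read-out, and the result is a number 16.9 percentage points higher from compound 3 to compound 4 (beyond the scatter) on this second core. The gain carries over, and the two steps cannot be told apart in size: the same change on two cores in this assay, a number 27.3 percentage points higher (beyond the scatter) from compound 1 to compound 2 and a number 16.9 percentage points higher (beyond the scatter) from compound 3 to compound 4, 10.4 percentage points apart, within the scatter of two such steps. For the compounds shown here, this rests on only two pairs with the chloro at a different place in each, so it does not show that the place is unimportant or that a further core would behave alike.

The compounds shown leave open whether the same place on either core would give the same step. They also leave open whether a group other than chloro, such as a methoxy group, an amine or a carboxylic acid, would raise the inhibition too.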